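This account rests on a few compounds, and the source may have more. Where it says the series, first, only, none or still open, it means among the compounds named here.

Measured so far:
compound 1, `O=C(Nc1cccc(/C=C/C(=O)c2nc3ccccc3[nH]2)c1)c1cccc(Br)c1`, gives 5210 nM in a functional assay on MCF7 cells (Homo sapiens) for antiproliferative activity, read by MTT assay, with a stated time of 48 h; a lower number here means a stronger inhibitor, a higher number a weaker inhibitor
compound 2, `O=C(/C=C/c1cccc(NS(=O)(=O)c2cccc(Cl)c2)c1)c1nc2ccccc2[nH]1`, gives 4160 nM

In this assay compound 2 has the lower of the two numbers, yet the step of a 1.3-fold lower number from compound 1 to compound 2 (0.10 log units; within the scatter) lies within the scatter. Compound 3, `Cc1cccc(S(=O)(=O)Nc2cccc(/C=C/C(=O)c3nc4ccccc4[nH]3)c2)c1`, differs from compound 2 by methyl in place of chloro on an aromatic carbon. Among the measured compounds shown here, no measured step bears on a change of this kind; the only step seen, a 1.3-fold lower number from compound 1 to compound 2 (0.10 log units; within the scatter), concerns a different part of the molecule and stayed within the scatter. For compound 3 the expected step is a 1.1-fold higher number from compound 2 to compound 3 (0.03 log units; within the scatter), not taken to exceed the scatter. The estimate for compound 3 is 4500 nM, ranging from 1800 nM to 11000 nM.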

Compound 3, half-maximal inhibitory concentration: 886 nM
Estimate against measurement, compound 3: 5.1-fold (0.71 log units) above; measured number outside the range, below it.
By their numbers in this assay, from the lowest: compound 3; then compounds 2 and 1 (each within the scatter of the next).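

In this assay the exchange of one heavy atom on this aromatic carbon, methyl in place of chloro, gives a 4.7-fold lower number from compound 2 to compound 3 (0.67 log units; beyond the scatter) and so passes the scatter, which the earlier step did not. The (3-methylphenyl)sulfonyl group also separates from the (3-bromophenyl)carbonyl group, with a 5.9-fold lower number from compound 1 to compound 3 (0.77 log units; beyond the scatter) where compound 2 stayed within the scatter of compound 1. Nothing measured here explains why this position responds so strongly to the change.

Whether the lower number is particular to methyl stays open, since the compounds shown do not say how ethyl, methoxy or an amine on this carbon would compare.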